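The source may report more compounds than this note shows. Statements on the series, on what has been measured and on what is new or still open speak of the compounds shown alone.

Of the compounds shown here, three of a shared core have been measured in a functional assay for inhibition, with Homo sapiens as the target; on this read-out lower numbers stand for stronger inhibition and higher numbers for weaker inhibition. Compound 1, `CSc1nncc2c(C)nc(C)n12`, gives only a limit of the assay, > 48000 nM, and so contributes no number; this is the line (the limit of > 48000 nM in this assay, at which 1 of the 3 values shown sits). Compound 2, `CCc1nc(C)c2cnn(CC)c(=O)n12`, gives 75600 nM in this assay. Compound 3, `CCc1nnc(O)n2c(C(C)(C)C)nc(C)c12`, gives 26000 nM in this assay, which is the lower of the two numbers available, and the gap from compound 2 to compound 3 lies beyond the usual scatter. Since compounds 2 and 3 differ in more than one place, the numbers show only where each stands, not what any single change did.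

Compound 4, `CCc1nnc(O)n2c(CC)nc(C)c12`, has not yet been measured. It differs from compound 3 by a single change: ethyl in place of tert-butyl on an aromatic carbon. The tert-butyl leaves and the smaller ethyl enters. Going by the values given here, no measured pair shows this change on its own, so no step can be read from the data. Compound 2, which carries an ethyl at the same place, gives a higher number than compound 3, but other differences stand alongside. A modest weakening is therefore expected, with the step from compound 3 to compound 4 estimated as a 1.7-fold higher number from compound 3 to compound 4 (0.24 log units; within the scatter). Compound 4 is estimated at 45000 nM in this assay, with a likely range from 15000 nM to 130000 nM.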

Compound 4, half-maximal inhibitory concentration: 24000 nM
For compound 4 the middle estimate is 1.9-fold (0.27 log units) above the measured one, and the stated range covers the measured number.
By their numbers in this assay, from the lowest: compounds 4 and 3 (each within the scatter of the next); then compound 2.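

Going by these compounds alone, the swap of tert-butyl for ethyl gives a 1.1-fold lower number from compound 3 to compound 4 (0.03 log units; within the scatter) in this assay, so this is the first single-place comparison. On an aromatic carbon between two ring nitrogen atoms, the two groups cannot be told apart in this assay, even though the chain drops from 4 heavy atoms to 2. This holds for this one pair only, and nothing measured here gives a reason for the result.

Going by these compounds, what remains open is whether the position tolerates other kinds of group, such as an amine, a carboxylic acid or a longer chain, or whether hydrogen there would give a number beyond the scatter. Also open, on these data alone, is whether any change at this place would hold on the other compounds of the shared core.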